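The source may hold more compounds than are shown below. What is called first, only, known or untested is meant among the compounds shown, and "the series" means these compounds.

In a functional assay on MDA-MB-231 cells (Homo sapiens) for inhibition, read by MTT assay, with a stated time of 72 h (on this read-out lower numbers stand for stronger inhibition and higher numbers for weaker inhibition), three compounds built on a shared core have been measured. Compound 3 `CC1=NN(c2ccccc2)C(=O)[C@]12C(=O)C=CC[C@H]2c1ccccc1` gives 5800 nM, compound 1 `CC1=NN(c2ccccc2)C(=O)[C@@]12C(=O)C=CC[C@@H]2c1ccc(C)cc1` gives 7420 nM, and compound 2 `COc1ccccc1[C@H]1CC=CC(=O)[C@@]12C(=O)N(c1ccccc1)N=C2C` gives 15700 nM. Compound 3 and compound 1 lie within the scatter of each other, and compound 2 shows a higher number than either, so compound 3 stands in the lower pair of this small set.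

Compound 4 `CC1=NN(c2ccccc2)C(=O)[C@@]12C(=O)C=CC[C@@H]2c1ccccc1` has not yet been measured. Its relation to compound 3 is the two compounds have the same atoms and bonds and differ only in configuration as drawn: 2 of 2 stereo elements differ (all stereocentres are inverted: mirror images); a stereocentre at a saturated ring carbon is drawn S in compound 3 and R in compound 4; a stereocentre at a saturated ring carbon is drawn S in compound 3 and R in compound 4. The two have the same atoms and bonds and are mirror images.

Among the measured compounds shown here, the one measured step, a 2.1-fold higher number from compound 1 to compound 2 (0.33 log units; beyond the scatter), exchanges an aryl group, with 2-methoxyphenyl in place of 4-methylphenyl on a saturated ring carbon. It is modest and leaves the configuration question untouched, so it bears on the inversion only loosely, as a guide to how far this small set moves. For the measured compounds named here, no mirror-image pair has been measured here, so the data fix neither the size nor the direction of such a change. With nothing pointing either way, the expected result is no step beyond the scatter in this assay. The estimated change is a 1.2-fold higher number from compound 3 to compound 4 (0.08 log units; within the scatter). For compound 4 the expected value is 7000 nM, with an estimated range from 3000 nM to 16000 nM.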

Compound 4, half-maximal inhibitory concentration: 9310 nM
Estimate against measurement, compound 4: 1.3-fold (0.12 log units) below, and the stated range covers the measured number.
By their numbers in this assay, from the lowest: compounds 3, 1, 4 and 2 (each within the scatter of the next, the first and the last beyond it).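

In this assay, the inversion of both stereocentres amounts to a 1.6-fold higher number from compound 3 to compound 4 (0.21 log units; within the scatter), so this read-out does not separate the two mirror images, and the comparison isolates configuration alone because of a single fact: the fact that compounds 3 and 4 differ only in the configuration as drawn Compound 4 also gives the first view of hydrogen on the aromatic carbon, and neither replacement moves the number beyond the scatter, with a 1.7-fold lower number from compound 2 to compound 4 (0.23 log units; within the scatter) and a 1.3-fold higher number from compound 1 to compound 4 (0.10 log units; within the scatter). Thus, although compound 1 and compound 2 stand apart through a 2.1-fold higher number from compound 1 to compound 2 (0.33 log units; beyond the scatter), compound 4 lies within the scatter of both, and among these compounds only that one step, between the two substituted aryl groups, is large enough to read as a change.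

As far as these compounds go, whether the mirror-image result also holds with 4-methylphenyl or 2-methoxyphenyl on the saturated ring carbon, or whether inverting a single stereocentre would behave as inverting both does, remains open. The compounds shown also leave open what an amine or a carboxylic acid on the aryl group, or a longer chain in place of the methyl on the shared core, would do in this assay.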